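The compounds below may be only part of what the source reports. "The series", "measured", "known", "first", "only" and "open" are said of these compounds alone.

Measured in an ADME assay on TZM cells (Homo sapiens) for cytotoxicity, read by CCK-8 assay, with a stated time of 2 days; a lower number here means that less compound is tolerated, a higher number that more compound is tolerated:
- compound 1 `CC(=O)Oc1ccc(/C=C/S(=O)(=O)CCc2ccc(NC(=O)c3ccc(C)cc3)cc2)cc1OC(C)=O`: 177000 nM
- compound 2 `O=C(Nc1ccc(CCS(=O)(=O)/C=C/c2ccc(O)c(O)c2)cc1)c1ccccc1`: 238000 nM
- compound 3 `O=C(Nc1ccc(CCS(=O)(=O)/C=C/c2ccc(O)c(O)c2)cc1)c1cc(F)cc(F)c1`: 414000 nM

Compound 3, at 414000 nM, lies within the scatter of compound 2 and beyond the scatter above compound 1.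

The next structure is compound 4 `Cc1ccc(C(=O)Nc2ccc(CCS(=O)(=O)/C=C/c3ccc(O)c(O)c3)cc2)cc1`, and the change is 4-methylphenyl in place of 3,5-difluorophenyl on a carbonyl carbon. In words, 4-methylphenyl stands in place of 3,5-difluorophenyl on a carbonyl carbon.

Going by the values given here, the one measured step at this place is a 1.7-fold higher number from compound 2 to compound 3 (0.24 log units; within the scatter), for phenyl going to 3,5-difluorophenyl. Compound 1 also carries 4-methylphenyl on that carbonyl carbon, but it differs elsewhere, so its 177000 nM is only loose support. Nothing measured isolates 4-methylphenyl itself. Leaving 3,5-difluorophenyl is expected to give back a small amount in this assay, with no shift beyond the scatter. The expected change is a 1.7-fold lower number from compound 3 to compound 4 (0.24 log units; within the scatter). For compound 4 the estimate is 240000 nM, with an expected range of 130000 nM to 420000 nM.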

Compound 4, half-maximal cytotoxic concentration: 168000 nM
Compound 4: the middle estimate sits 1.4-fold (0.15 log units) above what was measured, and the stated range covers the measured number.
By their numbers in this assay, from the lowest: compounds 4, 1, 2 and 3 (each within the scatter of the next, the first and the last beyond it).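

In this assay, the aryl group on the carbonyl carbon now gives a step beyond the scatter (a 2.5-fold lower number from compound 3 to compound 4 (0.39 log units; beyond the scatter)), whereas the earlier step at this place (a 1.7-fold higher number from compound 2 to compound 3 (0.24 log units; within the scatter)) stayed within it. Methyl in place of hydrogen on an aromatic carbon stays within the scatter (a 1.4-fold lower number from compound 2 to compound 4 (0.15 log units; within the scatter)), so the unsubstituted phenyl of compound 2 is not clearly separated from either substituted ring, and only 3,5-difluorophenyl and 4-methylphenyl stand apart. Nothing available explains this gap.

Going by these compounds, it remains open whether a single fluorine on the phenyl ring would keep the higher number of compound 3 or fall back towards compound 2. On these data alone, it is equally open where a methoxy group, a carboxylic acid or an amine on that ring would fall.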